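Cytotoxicity notes: carboxymethyl in place of chloro

The source may report more compounds than this note shows. Statements on the series, on what has been measured and on what is new or still open speak of the compounds shown alone.

The series shares one core; compound 1 is `CCOC(=O)CCCCCOc1cccc(CN(C(=O)c2ccc(-c3cccc(N(C)C)c3)cc2)C(C)C)c1`, compound 2 is `CCOC(=O)CCCCCOc1cccc(CN(C(=O)c2ccc(-c3ccc(C(C)=O)s3)cc2)C(C)C)c1` and compound 3 is `CCOC(=O)CCCCCOc1cccc(CN(C(=O)c2ccc(-c3cccc(Cl)c3)cc2)C(C)C)c1`. In an ADME assay on HEK293 cells (Homo sapiens) for cytotoxicity, read by CellTiter-Glo and resazurin assay, with a stated time of 72 h (on this read-out lower numbers stand for an effect already at smaller amounts and higher numbers for an effect only at larger amounts of compound), compound 1 gives only a limit, > 26000 nM. In this assay compound 2 likewise reaches only a limit, > 26000 nM. Compound 3 in this assay also stands at a limit, > 18400 nM, so no number places it against the other two. The step that the two limits leave unreadable from compound 1 to compound 2 and the step that the two limits leave unreadable from compound 1 to compound 3 are unreadable, as is a step that the two limits leave unreadable from compound 2 to compound 3, since the values rest on the limit of > 26000 nM in this assay, at which 2 of the 3 values shown sit, and on (the limit of > 18400 nM in this assay, at which 1 of the 3 values shown sits).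

Compound 4 is `CCOC(=O)CCCCCOc1cccc(CN(C(=O)c2ccc(-c3cccc(CC(=O)O)c3)cc2)C(C)C)c1`. It differs from compound 3 by carboxymethyl in place of chloro on an aromatic carbon. Going by the values given here, none of the measured steps has a readable size, so the only guide is that the three measured compounds all sit at limits in this assay. The expected step is a step that the limit leaves unreadable from compound 3 to compound 4, nothing beyond the scatter. Compound 4 is estimated at 30000 nM in this assay, with a range from 15000 nM to 60000 nM, and is most likely reported again only as a limit.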

Compound 4, half-maximal effective concentration: > 26000 nM
Compound 4 was reported as a limit; the forecaster's own chance of this, stated with the estimate: 85%; the middle value is on the limit's open side.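

In this assay compound 4 gives only a limit, > 26000 nM. All four values are limits, so the steps from compound 1, compound 2 and compound 3 to compound 4 cannot be read. The compounds shown leave open at what concentration any of the four reaches the half-maximal effect, and whether any exchanged group shifts that concentration.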